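This account rests on a few compounds, and the source may have more. Where it says the series, first, only, none or still open, it means among the compounds named here.

Compound 3 `C=CCc1cc(C(C)=O)c(O)cc1OCCCCCC(C)(C)O` gives the highest of the three numbers recorded so far in an assay on isolated protein for binding affinity to leukotriene B4 receptor 1 (Homo sapiens), tested at 1 uM (a higher number here means more inhibition at the concentration tested (going by the name of the read-out), a lower number less inhibition), namely 60%. Compound 2 `C=CCc1cc(C(C)=O)c(O)cc1OCCCCCC#N` comes nearest, with a reading in this assay of 41%, and compound 1 `C=CCc1cc(C(C)=O)c(O)cc1OCCCC#N` lies furthest off, with a reading in this assay of 6%. The measured steps all run upward: a number 35 percentage points higher from compound 1 to compound 2 (beyond the scatter), a number 54 percentage points higher from compound 1 to compound 3 (beyond the scatter), and a number 19 percentage points higher from compound 2 to compound 3 (beyond the scatter).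

Compound 4 `C=CCc1cc(C(C)=O)c(O)cc1OCCCCCC(=O)NO` is not yet measured in this assay. It differs from compound 3 in one place: hydroxycarbamoyl in place of 1-hydroxy-1-methylethyl on a saturated chain carbon, five bonds along the chain from an oxygen on an aromatic ring. For the measured compounds named here, the step that bears most directly on this change is the one from compound 2 to compound 3, which swapped one chain end for another at the same place on the chain and was modest in size, a number 19 percentage points higher from compound 2 to compound 3 (beyond the scatter). Going by the values given here, that step shows the chain end matters in this assay at the same chain length, but no measured pair shows what hydroxycarbamoyl does there. A step of modest size in either direction is therefore plausible, and a small downward drift is taken as the middle case. Compound 4 is expected to give about 50% in this assay, within the range 25% to 72%, meaning an estimated step of a number 10 percentage points lower from compound 3 to compound 4 (within the scatter).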

Compound 4, a percentage reported as inhibition, at one concentration (the size of the read-out at that concentration, not a potency): 28%
Estimate against measurement, compound 4: 22 percentage points above; the measured number falls inside the stated range.
By their numbers in this assay, from the lowest: compound 1; then compound 4; then compound 2; then compound 3.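

Exchanging the tertiary alcohol end for hydroxycarbamoyl at this place on the chain costs more in this assay than any earlier comparison at this chain length suggested: a number 32 percentage points lower from compound 3 to compound 4 (beyond the scatter), and the change from the nitrile end also falls, a number 13 percentage points lower from compound 2 to compound 4 (beyond the scatter), so at this chain length the three ends now separate, with hydroxycarbamoyl lowest, the nitrile in the middle and 1-hydroxy-1-methylethyl highest. The two groups being exchanged have the same heavy-atom count, so that count alone does not set the reading here, whereas the hydrogen-bond donor and acceptor counts do differ between them. Compound 4 still reads above the short nitrile, a number 22 percentage points higher from compound 1 to compound 4 (beyond the scatter), but this step changes both chain length and chain end, and no evidence is available on why hydroxycarbamoyl gives the lower reading.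

The compounds shown leave open how a carboxylic acid, a primary amide or an amine would read at the same chain end, and whether a longer chain would shift the order of these ends. Since each reading comes from a single concentration, they also leave open how far these differences would carry over to potency.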